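The compounds below may be only part of what the source reports. "The series", "measured", "known", "first", "only" and "open" are said of these compounds alone.

Compound 2 `CCNC(C(=O)O)c1cc(O)no1` is one of two measured compounds that share a core and differ only in the group on the amine nitrogen. In a functional assay for agonist activity at metabotropic glutamate receptor 1 (Rattus norvegicus) (a higher number here means that more compound is needed for the effect, a lower number that less compound is needed), compound 2 gives > 1000000 nM, which is a limit of the assay and not a number. Its neighbour compound 1 `CNC(C(=O)O)c1cc(O)no1` likewise gives in this assay > 1000000 nM, again a limit rather than a number. The step from compound 1 to compound 2 is therefore a step that the two limits leave unreadable from compound 1 to compound 2, and the only pattern so far is the limit of > 1000000 nM in this assay, at which 2 of the 2 values shown sit.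

Compound 3 `O=C(O)C(NCc1ccccc1)c1cc(O)no1` is the next compound along this path. The change from compound 2 to compound 3 is phenyl in place of methyl on a saturated chain carbon bound to an amine nitrogen. Among the compounds with values here, no measured step bears on this change with a readable size, since the step from compound 1 to compound 2 is hidden by two limits. With both known values resting at the same limit, the step from compound 2 to compound 3 is expected to be a number no higher from compound 2 to compound 3 (the limit leaves the size open), that is, nothing that can be read beyond the scatter. Compound 3 is accordingly estimated at 1000000 nM, with a range from 200000 nM to 5000000 nM, and most likely this assay will again report only a limit.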

Compound 3, half-maximal effective concentration: > 1000000 nM
Compound 3: a limit, no number; the forecaster's own chance of this, stated with the estimate: 80%; the middle value sits exactly at the limit.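

In this assay compound 3 gives > 1000000 nM, which is a limit of the assay and not a number. Within the data shown here, no step among compound 1, compound 2 and compound 3 can be read, and the only pattern remains: the limit of > 1000000 nM in this assay, at which 3 of the 3 values shown sit. The compounds shown leave open whether any group on the amine nitrogen of the shared core would give a measurable value.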